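Lengthening the Amine Chain on a Thromboxane Synthase Inhibitor

A few compounds are considered here, and "the series" means these few. Any claim that something is new, unique, unknown or untested is made for them only; others in the source may bear on it.

In a functional assay for inhibition of Thromboxane-A synthase (Rattus norvegicus) (a higher number here means a weaker inhibitor, a lower number a stronger inhibitor), compound 1 `CNc1nc2c(C)c(Cc3cccnc3)c(O)c(C)c2s1` is recorded only as a limit of the assay, < 100 nM. That value is the limit of < 100 nM in this assay, at which 1 of the 3 values shown sits. Two related compounds, with the groups arranged differently on the shared core, give numbers: compound 2 `CCNc1nc2c(C)c(C)c(O)c(Cc3cccnc3)c2s1` gives 2000 nM, and compound 3 `CCCNc1nc2c(Cc3cccnc3)c(C)c(O)c(C)c2s1` gives 90 nM. Compound 4 `CCNc1nc2c(C)c(Cc3cccnc3)c(O)c(C)c2s1` differs from compound 1 by methyl in place of hydrogen on a saturated chain carbon bound to a nitrogen on an aromatic ring. Among the measured compounds shown here, no measured pair isolates this change, so the step is expected to be small, within the usual scatter, with no clear direction. Compound 4 is therefore expected to give 70 nM, within a range of 20 nM to 300 nM. The expected step from compound 1 to compound 4 is a step that the limit leaves unreadable from compound 1 to compound 4.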

Compound 4, half-maximal inhibitory concentration: 650 nM
Compound 4: the middle estimate sits 9.3-fold (0.97 log units) below what was measured; the whole stated range lies below it.
By their numbers in this assay, from the lowest: compound 3; then compound 4; then compound 2.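

On the shared core, methyl in place of hydrogen on a saturated chain carbon bound to a nitrogen on an aromatic ring, which turns methylamino into ethylamino, gives an at least 6.5-fold higher number from compound 1 to compound 4 (0.81 log units; beyond the scatter) in this assay. So inhibition at this position responds to even this small lengthening of the amine chain. The true size of the step stays unknown, and can only be larger than stated, since the value for compound 1 is a limit: the limit of < 100 nM in this assay, at which 1 of the 4 values shown sits.

From the compounds shown here alone, whether an unsubstituted amine or a longer chain such as butylamino, with the groups arranged as in compound 4, would strengthen or further weaken inhibition remains open.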